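A Second Look at One Ring Swap

The compounds below may be only part of what the source reports. "The series", "measured", "known", "first", "only" and "open" are said of these compounds alone.

Compound 1 `Oc1ccc(O)c(-c2cc(-c3ccc(Cl)cc3)nn2-c2ccccc2)c1`: 32500 nM
Compound 2 `CC(=O)NS(=O)(=O)c1ccc(-n2nc(-c3ccccc3)cc2-c2cc(O)ccc2O)cc1`: 100000 nM
Compound 3 `O=C1C=CC(=O)C(c2cc(-c3ccc(Cl)cc3)nn2-c2ccccc2)=C1`: 55400 nM

Of the compounds shown here, three have been tested in a functional assay on cells (Melanoma cell, Homo sapiens) for cytotoxicity, read by sulforhodamine B assay, with a stated time of 48 h; on this read-out lower numbers stand for stronger inhibition of growth and higher numbers for weaker inhibition of growth. Compound 1 gives 32500 nM, compound 3 gives 55400 nM, and compound 2 gives 100000 nM. Compound 3 comes from compound 1 by a single change, (a group of 8 heavy atoms (6 carbon, 2 oxygen; one six-membered non-aromatic ring of carbon only) in place of a group of 8 heavy atoms (6 carbon, 2 oxygen; one six-membered aromatic ring of carbon only), on an aromatic carbon), which produced a 1.7-fold higher number from compound 1 to compound 3 (0.23 log units; within the scatter). The difference between the cores of compound 1 and compound 2 is not broken down here. Compound 4 `CC(=O)NS(=O)(=O)c1ccc(-n2nc(-c3ccccc3)cc2C2=CC(=O)C=CC2=O)cc1` has not yet been measured; it arises from compound 2 by the same kind of change, (a group of 8 heavy atoms (6 carbon, 2 oxygen; one six-membered non-aromatic ring of carbon only) in place of a group of 8 heavy atoms (6 carbon, 2 oxygen; one six-membered aromatic ring of carbon only), on an aromatic carbon). The surroundings differ: in compound 1 the place is next to the ring atom that bears a phenyl group and two ring bonds from the ring atom that bears a 4-chlorophenyl group, while in compound 2 it is next to the ring atom that bears a large group and two ring bonds from the ring atom that bears a phenyl group. Because a 1.7-fold higher number from compound 1 to compound 3 (0.23 log units; within the scatter) stayed within the scatter, compound 4 is expected to show a similar step, a 1.5-fold higher number from compound 2 to compound 4 (0.18 log units; within the scatter). The estimate for compound 4 in this assay is 150000 nM, between 60000 nM and 400000 nM.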

Compound 4, concentration for total growth inhibition: 100000 nM
Compound 4: middle estimate off by 1.5-fold (0.18 log units), on the high side, within the range that was stated.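

In this assay, putting the non-aromatic ring in place of the 2,5-dihydroxyphenyl group produced no change at the digits printed from compound 2 to compound 4 (within the scatter). Set beside the earlier step on the other core, the same change shows no difference that can be told apart from ordinary variation between repeated measurements: the same change on two cores in this assay, a 1.7-fold higher number (0.23 log units; within the scatter) from compound 1 to compound 3 and no change at the digits printed (within the scatter) from compound 2 to compound 4, 1.7-fold (0.23 log units) apart, within the scatter of two such steps This shows that on these two cores the swap left the number within the scatter, but it does not show that the same would hold on a third core, and it does not explain why the number stays put.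

The compounds shown leave open whether a different group on that aromatic carbon, such as an amine or a carboxylic acid, would move the number beyond the scatter. They also leave open what each difference between the core of compound 1 and the core of compound 2 contributes on its own.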